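Aryl swap on the shared core: compound 2 to compound 3

The compounds below may be only part of what the source reports. "The series", "measured", "known", "first", "only" and "open" are said of these compounds alone.

Compound 1 `CCCCCCCCCCCCNc1nc(SCc2ccc(C(F)(F)F)cc2)nc2ccccc12` and compound 2 `FC(F)(F)c1ccc(CSc2nc(Nc3ccccc3Cl)c3ccccc3n2)cc1` share one core and differ on the amine. In a functional assay on MDA-MB-231 cells (Homo sapiens) for cytotoxicity, read by MTT assay, with a stated time of 72 h (a higher number here means a weaker inhibitor, a lower number a stronger inhibitor), compound 1 gives only a limit, > 50000 nM. In this assay compound 2 likewise reaches only a limit, > 50000 nM. Both values sit at the limit of > 50000 nM in this assay, at which 2 of the 2 values shown sit, so compound 2 stands nowhere distinct on the numbers shown. Compound 3 `O=[N+]([O-])c1cccc(Nc2nc(SCc3ccc(C(F)(F)F)cc3)nc3ccccc23)c1` differs from compound 2 by 3-nitrophenyl in place of 2-chlorophenyl on a nitrogen on an aromatic ring. Among the compounds with values here, with no measured step available, the change is expected to stay within the scatter, a number no higher from compound 2 to compound 3 (the limit leaves the size open). Compound 3 is estimated at 50000 nM, between 15000 nM and 150000 nM.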

Compound 3, half-maximal inhibitory concentration: 31500 nM
The estimate for compound 3 lay 1.6-fold (0.20 log units) above the measured number, and the stated range covers the measured number.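

Within the data shown here, compound 3 is the first compound here with a number rather than a limit in this assay: compound 3 gives 31500 nM. On the nitrogen on an aromatic ring, 3-nitrophenyl in place of 2-chlorophenyl gives an at least 1.5-fold lower number from compound 2 to compound 3 (0.20 log units; that floor lies within the scatter). Going by these compounds, compound 2 gives a limit, > 50000 nM, so the true size of the step stays open.

On these data alone, whether an amine or a carboxylic acid in place of the nitro group of compound 3 would keep a measurable number remains open. Most of the series shown still gives no number: the limit of > 50000 nM in this assay, at which 2 of the 3 values shown sit.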